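Swapping the (methoxymethoxy)methyl group of compound 2

The source may report more compounds than this note shows. Statements on the series, on what has been measured and on what is new or still open speak of the compounds shown alone.

Measured in a functional assay on SMMC-7721 cells (Homo sapiens) for antiproliferative activity, read by MTT assay, with a stated time of 48 h; on this read-out higher numbers stand for weaker inhibition and lower numbers for stronger inhibition:
Compound 1 `COC/C1=C/C[C@](C)(CCC=C(C)C)/C=C/[C@@H](OC(=O)C=C(C)C)[C@](C)(O)/C=C/C1=O`: 11000 nM
Compound 2 `COCOC/C1=C/C[C@](C)(CCC=C(C)C)/C=C/[C@@H](OC(=O)C=C(C)C)[C@](C)(O)/C=C/C1=O`: 3250 nM

Of these two, compound 2 holds the lower number, at 3250 nM. Compound 3 `CO/N=C/C1=C/C[C@](C)(CCC=C(C)C)/C=C/[C@@H](OC(=O)C=C(C)C)[C@](C)(O)/C=C/C1=O` differs from it in one group, on a double-bonded ring carbon: a group of 4 heavy atoms (2 carbon, 1 nitrogen, 1 oxygen; no ring) in place of a group of 5 heavy atoms (3 carbon, 2 oxygen; no ring), on a double-bonded ring carbon. Within the data shown here, the only measured step that bears on this change is a 3.4-fold lower number from compound 1 to compound 2 (0.53 log units; beyond the scatter), modest but beyond the scatter. Among the measured compounds shown here, no measured compound carries the entering group, so the direction is uncertain. A modest rise in this assay is expected, with the estimated step being a 1.7-fold higher number from compound 2 to compound 3 (0.23 log units; within the scatter). Compound 3 is estimated at 5500 nM, with an expected range from 2000 nM to 15000 nM.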

Compound 3, half-maximal inhibitory concentration: 3470 nM
The estimate for compound 3 lay 1.6-fold (0.20 log units) above the measured number; measured number inside the range.
By their numbers in this assay, from the lowest: compounds 2 and 3 (each within the scatter of the next); then compound 1.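

In this assay, the step of a 1.1-fold higher number from compound 2 to compound 3 (0.03 log units; within the scatter) shows that the (methoxymethoxy)methyl group and the entering group of 4 heavy atoms cannot be told apart at this double-bonded ring carbon. The step of a 3.2-fold lower number from compound 1 to compound 3 (0.50 log units; beyond the scatter) shows that the lower number seen earlier is not confined to the (methoxymethoxy)methyl group. Nothing measured here explains either step. Going by these compounds, whether an amine, a carboxylic acid or a longer chain on this carbon would keep the number at this level remains open.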